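This account rests on a few compounds, and the source may have more. Where it says the series, first, only, none or still open, it means among the compounds named here.

Compound 3, with structure `O=C(NCCNc1nccc(-c2c(-c3cccc(F)c3)nc3sccn23)n1)c1ccc(Cl)cc1`, gives the lowest of the two numbers shown in a functional assay on SK-MEL-28 cells (Homo sapiens) for cytotoxicity, read by MTT assay; a lower number here means a stronger inhibitor, a higher number a weaker inhibitor. Its value is 8160 nM. Compound 2, of structure `O=S(=O)(NCCCNc1nccc(-c2c(-c3cccc(F)c3)nc3sccn23)n1)c1ccc(C(F)(F)F)cc1`, sits nearest, with 11700 nM, a gap that stays within the scatter, so no order between the two can be claimed. Compound 1, of structure `O=C(NCCCNc1nccc(-c2c(-c3cccc(F)c3)nc3sccn23)n1)c1ccc(F)cc1`, is recorded only as a limit of the assay, > 20000 nM, the line the limit of > 20000 nM in this assay, at which 1 of the 3 values shown sits, at which its value rests. Among the measured compounds shown here, the one measured step joining these compounds, an at least 2.4-fold lower number from compound 1 to compound 3 (0.38 log units; beyond the scatter), is at least modest in size, but it changes both the linking chain and the halogen at once and therefore does not speak cleanly to the change now in question.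

Compound 4, with structure `Cc1ccc(C(=O)NCCNc2nccc(-c3c(-c4cccc(F)c4)nc4sccn34)n2)cc1`, differs from compound 3 by methyl in place of chloro on an aromatic carbon. No measured pair among these compounds isolates a methyl in place of a chloro on the six-membered aromatic ring of carbon only, so there is no direct evidence on which to expect a shift in either direction. The account therefore expects a step of a 1.0-fold lower number from compound 3 to compound 4 (0.01 log units; within the scatter), that is, none beyond the scatter. For compound 4 the estimate in this assay is 8000 nM, with a range from 3500 nM to 18000 nM.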

Compound 4, half-maximal inhibitory concentration: 18800 nM
Compound 4: middle estimate off by 2.4-fold (0.37 log units), on the low side; measured number outside the range, above it.
By their numbers in this assay, from the lowest: compounds 3, 2 and 4 (each within the scatter of the next, the first and the last beyond it). At a limit, above all of these: compound 1.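

Methyl in place of chloro on an aromatic carbon, on the six-membered aromatic ring of carbon only and para to a large group, gives in this assay a 2.3-fold higher number from compound 3 to compound 4 (0.36 log units; beyond the scatter). This is the one step among these compounds that changes a single group on this ring. The step is modest, but it shows that this position is not indifferent to the exchange, even though the two groups each count one heavy atom and neither brings a ring, a hydrogen-bond donor or acceptor, or a net charge. Compound 1 is recorded only as a limit: the limit of > 20000 nM in this assay, at which 1 of the 4 values shown sits. The step of an at least 1.0-fold lower number from compound 1 to compound 4 (0.02 log units; that floor lies within the scatter) therefore gives only a floor and cannot be read further.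

As far as these compounds go, what a methoxy group, a nitrile, a bromo group or a plain hydrogen would give at this position on the background of compound 3 stays open, so one step cannot say whether chloro is unusual here or methyl is. Also open, from the compounds shown here alone, is whether the same exchange gives a step of similar size with a longer chain between the amide and the shared core.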